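This account rests on a few compounds, and the source may have more. Where it says the series, first, only, none or still open, it means among the compounds named here.

In a functional assay on MT4 cells (Homo sapiens) for cytotoxicity (a higher number here means that more compound is tolerated, a lower number that less compound is tolerated), the three measured compounds span a fair range. Compound 1 `COc1ncnc2c1ncn2[C@@H]1O[C@H](CO[Si](C)(C)C(C)(C)C)[C@@]2(OS(=O)(=O)C=C2N)[C@H]1O[Si](C)(C)C(C)(C)C` gives 21000 nM, and compound 2 `CC(C)(C)[Si](C)(C)OC[C@H]1O[C@@H](n2cnc3c(O)ncnc32)[C@H](O[Si](C)(C)C(C)(C)C)[C@]12OS(=O)(=O)C=C2N` gives 14000 nM; the step from compound 1 to compound 2 a 1.5-fold lower number from compound 1 to compound 2 (0.18 log units; within the scatter) is a small one, a hydrogen in place of a methyl on an oxygen on an aromatic ring. Compound 3 `COc1ccc(C(Nc2ncnc3c2ncn3[C@@H]2O[C@H](CO[Si](C)(C)C(C)(C)C)[C@@]3(OS(=O)(=O)C=C3N)[C@H]2O[Si](C)(C)C(C)(C)C)(c2ccccc2)c2ccccc2)cc1` gives 192000 nM, the highest of the three numbers and beyond the scatter from compound 2. Compound 2 thus holds the lowest number of the set, though it is within the scatter of compound 1.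

Compound 4 `CC(C)(C)[Si](C)(C)OC[C@H]1O[C@@H](n2cnc3c(N)ncnc32)[C@H](O[Si](C)(C)C(C)(C)C)[C@]12OS(=O)(=O)C=C2N` is the next to be tested. It differs from compound 2 only in amino in place of hydroxy on an aromatic carbon, an amino in place of a hydroxy on an aromatic carbon. Among the compounds with values here, the only single-point step measured so far is that from compound 1 to compound 2 a 1.5-fold lower number from compound 1 to compound 2 (0.18 log units; within the scatter), which touched the same position of the shared core and stayed within the scatter. With one such step to lean on, a change no larger than the scatter is expected in this assay for compound 4, in either direction, so that the step from compound 2 to compound 4 a 1.3-fold higher number from compound 2 to compound 4 (0.11 log units; within the scatter) is estimated to be modest. Compound 4 is therefore expected to give about 18000 nM, within a range from 7000 nM to 60000 nM.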

Compound 4, half-maximal cytotoxic concentration: 13000 nM
Compound 4: the middle estimate sits 1.4-fold (0.14 log units) above what was measured; the measured number falls inside the stated range.
By their numbers in this assay, from the lowest: compounds 4, 2 and 1 (each within the scatter of the next); then compound 3.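

In this assay, the aromatic carbon has now carried methoxy, hydroxy and amino, and both new steps, a 1.1-fold lower number from compound 2 to compound 4 (0.03 log units; within the scatter) and a 1.6-fold lower number from compound 1 to compound 4 (0.21 log units; within the scatter), stay within the scatter. Where the earlier compounds offered a single exchange at this place, compound 4 adds a second and a third comparison, and none of the three small groups can be told apart from the others in this assay; the pattern holds for compounds 1, 2 and 4 only, and compound 3, with a monomethoxytrityl group on that amino, stands apart at 192000 nM. Nothing measured here accounts for how little these exchanges register.

The compounds shown leave open whether a small group of another kind at this position, such as chlorine, a carboxylic acid or a dimethylamino group, would also stay within the scatter of compound 4. They also leave open how far a substituent on the amino can grow before the number moves away from that of compound 4, since only the monomethoxytrityl group of compound 3 stands between these extremes.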